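Replacing 3,4-dichlorophenyl with 3,5-dimethoxyphenyl

The compounds below may be only part of what the source reports. "The series", "measured", "known", "first", "only" and "open" are said of these compounds alone.

For the measured compounds named here, in a functional assay on CCRF-CEM cells (Homo sapiens) for antiproliferative activity, with a stated time of 72 h (a lower number here means a stronger inhibitor, a higher number a weaker inhibitor), compound 2 `OC[C@H]1O[C@@H](n2cnc3c(NCc4ccc(Cl)c(Cl)c4)ncnc32)[C@H](O)[C@@H]1O` gives 3800 nM, the lower of the two numbers so far, and compound 1 `OC[C@H]1O[C@@H](n2cnc3c(NCc4ccc(Br)cc4)ncnc32)[C@H](O)[C@@H]1O` gives 20600 nM. Compound 3 `COc1cc(CNc2ncnc3c2ncn3[C@@H]2O[C@H](CO)[C@@H](O)[C@H]2O)cc(OC)c1` has not yet been measured, and it differs from compound 2 in one group: 3,5-dimethoxyphenyl in place of 3,4-dichlorophenyl on a saturated chain carbon bound to a nitrogen on an aromatic ring. Going by the values given here, the only measured step at this place, a 5.4-fold lower number from compound 1 to compound 2 (0.73 log units; beyond the scatter), shows that changing this group can move the number beyond the scatter. Among the compounds with values here, no measured compound carries methoxy groups, so the direction is uncertain, but a similar move upward seems likeliest, with an expected 2.6-fold higher number from compound 2 to compound 3 (0.42 log units; beyond the scatter). Compound 3 is estimated at 10000 nM, within a range of 3000 nM to 35000 nM.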

Compound 3, half-maximal inhibitory concentration: > 166000 nM
Compound 3 ended at the assay's limit; the forecaster's own chance of this, stated with the estimate: 15%; middle value at least 16-fold (1.22 log units) away from the limit.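

Compound 3 reads only as a limit in this assay, not as a number: the limit of > 166000 nM in this assay, at which 1 of the 3 values shown sits. Putting 3,5-dimethoxyphenyl at this place gives an at least 43-fold higher number from compound 2 to compound 3 (1.64 log units; beyond the scatter), so the group here can take the result out of the measurable range rather than only shift it. The same change also gives an at least 8.0-fold higher number from compound 1 to compound 3 (0.90 log units; beyond the scatter), so the loss holds against the weaker of the two earlier compounds as well.

Going by these compounds, whether the two methoxy groups or their arrangement on the ring drives this remains open. So does the outcome with a single methoxy group, an amine or a carboxylic acid on this phenyl ring.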